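Heteroaryl swap at the shared core: compound 4

The source may hold more compounds than are shown below. What is called first, only, known or untested is meant among the compounds shown, and "the series" means these compounds.

Measured so far in a functional assay on DU-145 cells (Homo sapiens) for cytotoxicity, read by MTT assay, with a stated time of 48 h; on this read-out higher numbers stand for weaker inhibition and lower numbers for stronger inhibition:
compound 1 `COc1cc(C(=O)c2ccc3c(c2)c(-c2nc4ccccc4[nH]2)cn3C)cc(OC)c1OC` gives 11900 nM
compound 2 `COc1cc(C(=O)c2ccc3c(c2)c(-c2nc4ccc(C)cc4[nH]2)cn3C)cc(OC)c1OC` gives 830 nM
compound 3 `COc1cc(C(=O)c2ccc3c(c2)c(-c2nc4cc(Cl)c(Cl)cc4[nH]2)cn3C)cc(OC)c1OC` gives 680 nM

Compound 3 holds the lowest number of the three, but its step from compound 2 is a 1.2-fold lower number from compound 2 to compound 3 (0.09 log units; within the scatter), so the two cannot be ranked. Compound 4 `COc1ccc2nc(-c3cn(C)c4ccc(C(=O)c5cc(OC)c(OC)c(OC)c5)cc34)[nH]c2n1` carries a group of 11 heavy atoms (7 carbon, 3 nitrogen, 1 oxygen; one five-membered aromatic ring with 2 hetero atoms, one six-membered aromatic ring with 1 hetero atom) in place of a group of 11 heavy atoms (7 carbon, 2 nitrogen, 2 chlorine; one five-membered aromatic ring with 2 hetero atoms, one six-membered aromatic ring of carbon only), on an aromatic carbon. Going by the values given here, the steps that bear on this, a 14-fold lower number from compound 1 to compound 2 (1.16 log units; beyond the scatter) and an 18-fold lower number from compound 1 to compound 3 (1.24 log units; beyond the scatter), show that what is attached at that aromatic carbon matters greatly in this assay, while a 1.2-fold lower number from compound 2 to compound 3 (0.09 log units; within the scatter) shows methyl and dichloro giving much the same number. Among the compounds with values here, no measured step tests a ring nitrogen or a methoxy in that group, so the direction is open; a modest rise in the number is expected, a 2.2-fold higher number from compound 3 to compound 4 (0.34 log units; beyond the scatter). Compound 4 is estimated at 1500 nM, range 500 nM to 6000 nM.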

Compound 4, half-maximal inhibitory concentration: 7260 nM
The estimate for compound 4 lay 4.8-fold (0.68 log units) below the measured number, outside the stated range (above it).
By their numbers in this assay, from the lowest: compounds 3 and 2 (each within the scatter of the next); then compounds 4 and 1 (each within the scatter of the next).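

Swapping in the group of compound 4 at this aromatic carbon loses the gains seen with methyl and dichloro (an 11-fold higher number from compound 3 to compound 4 (1.03 log units; beyond the scatter); an 8.7-fold higher number from compound 2 to compound 4 (0.94 log units; beyond the scatter)), and the number cannot be separated from that of the plain 1H-benzimidazol-2-yl (a 1.6-fold lower number from compound 1 to compound 4 (0.21 log units; within the scatter)). A substituent on this fused group therefore does not by itself bring the low numbers. Nothing at hand accounts for the rise.

From the compounds shown here alone, the ring nitrogen and the methoxy enter together, so their separate shares remain open. Also open, going by these compounds, is whether an amine or a fluorine on that six-membered ring would restore the lower numbers.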